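Pyridine position and a chloro-for-methyl swap on a fused core

The compounds below may be only part of what the source reports. "The series", "measured", "known", "first", "only" and "open" are said of these compounds alone.

Measured compounds:
compound 1, `Cc1cn2c(/C=N/NC(=N)N)c(-c3ccncc3)nc2s1`, 34700 nM
compound 2, `Cc1cn2c(/C=N/NC(=N)N)c(-c3cccnc3)nc2s1`, 7080 nM
compound 3, `N=C(N)N/N=C/c1c(-c2cccnc2)nc2sc(Cl)cn12`, 16600 nM

All three were tested in a functional assay (Homo sapiens) for antiproliferative activity; on this read-out lower numbers stand for stronger inhibition of growth and higher numbers for weaker inhibition of growth. Compound 2 gives the lowest number of the three, and compound 1 the highest. Two single changes connect them. From compound 2 to compound 1 the change is pyridin-4-yl in place of pyridin-3-yl on an aromatic carbon, and it brought a 4.9-fold higher number from compound 2 to compound 1 (0.69 log units; beyond the scatter). From compound 2 to compound 3 the change is chloro in place of methyl on an aromatic carbon, and it brought a 2.3-fold higher number from compound 2 to compound 3 (0.37 log units; beyond the scatter). Compound 3 thus sits between the other two in this assay.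

Compound 4, `N=C(N)N/N=C/c1c(-c2ccncc2)nc2sc(Cl)cn12`, has not yet been measured. It differs from compound 3 by pyridin-4-yl in place of pyridin-3-yl on an aromatic carbon. This is the same change that was made from compound 2 to compound 1, made here on the core of compound 3 rather than the core of compound 2; the two cores differ by chloro in place of methyl on an aromatic carbon, and the surroundings of the place where the pyridine is swapped are described in the same words in both cases.

Within the data shown here, with only one earlier example of this change, the expectation rests on it alone: compound 4 is expected to show a step from compound 3 of about a 4.2-fold higher number from compound 3 to compound 4 (0.62 log units; beyond the scatter), because the same change gave a 4.9-fold higher number from compound 2 to compound 1 (0.69 log units; beyond the scatter). On that basis compound 4 is estimated at about 70000 nM in this assay, with a wide range of 30000 nM to 160000 nM.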

Compound 4, concentration for 50% growth inhibition: 13200 nM
Beside the measured number, compound 4's estimate is 5.3-fold (0.72 log units) above it; the whole stated range lies above it.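

In this assay, the swap of pyridin-3-yl for pyridin-4-yl did not carry over from one core to the other: on the core bearing chloro it gave a 1.3-fold lower number from compound 3 to compound 4 (0.10 log units; within the scatter), so this pair cannot be told apart, and the gap to the same swap on the core bearing methyl is real: the same change on two cores in this assay, a 4.9-fold higher number (0.69 log units; beyond the scatter) from compound 2 to compound 1 and a 1.3-fold lower number (0.10 log units; within the scatter) from compound 3 to compound 4, 6.2-fold (0.79 log units) apart, beyond the scatter of two such steps Read the other way, the chloro-for-methyl change also depends on its partner, since with pyridin-4-yl in place it gave a 2.6-fold lower number from compound 1 to compound 4 (0.42 log units; beyond the scatter), the opposite direction to what it did with pyridin-3-yl: the same change on two cores in this assay, a 2.3-fold higher number (0.37 log units; beyond the scatter) from compound 2 to compound 3 and a 2.6-fold lower number (0.42 log units; beyond the scatter) from compound 1 to compound 4, 6.2-fold (0.79 log units) apart, beyond the scatter of two such steps So in these four compounds the effect of each change depends on the group present at the other place, which means a step measured on one core is a poor guide to the next, but the numbers do not show why this happens or whether it holds beyond this small set.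

From the compounds shown here alone, how a phenyl ring in place of the pyridine would behave, or a bromo or ethyl group in place of the chloro or methyl, stays open. With two groups at each of the two places, it is also unknown whether this dependence is general in the series or specific to these groups.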